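Bromo for hydrogen on the benzyl arm, two cores

A few compounds are considered here, and "the series" means these few. Any claim that something is new, unique, unknown or untested is made for them only; others in the source may bear on it.

Compound 1 `O=C(/C=C/c1ccc(OCc2cn(Cc3ccccc3)nn2)cc1)c1ccc(Br)cc1` and compound 2 `O=C(/C=C/c1ccc(OCc2cn(Cc3ccc(Br)cc3)nn2)cc1)c1ccc(Br)cc1` share one core and differ only on the benzyl arm. In a functional assay on MCF7 cells (Homo sapiens) for inhibition, read by MTT assay, with a stated time of 48 h, tested at 10 uM (on this read-out lower numbers stand for less inhibition of growth and higher numbers for more inhibition of growth at the one concentration tested), compound 1 gives 34%, and compound 2 gives 23%. The change bromo in place of hydrogen on an aromatic carbon therefore produced a number 11 percentage points lower from compound 1 to compound 2 (beyond the scatter).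

Compound 3 `O=C(/C=C/c1ccc(OCc2cn(Cc3ccccc3)nn2)cc1)c1ccc([N+](=O)[O-])cc1` carries a different core; the two cores differ by nitro in place of bromo on an aromatic carbon. In this assay, among the compounds with values here, compound 3 is recorded as "not active" (no number reported), with no number given, so no step can be computed from it.

Compound 4 `O=C(/C=C/c1ccc(OCc2cn(Cc3ccccc3Br)nn2)cc1)c1ccc([N+](=O)[O-])cc1` has not been measured. It is related to compound 3 by bromo in place of hydrogen on an aromatic carbon. This is the same kind of change as the one from compound 1 to compound 2, and it occurs twice among the compounds shown, but the two are not the same: in compound 2 the entering bromo stands para to a large group, whereas in compound 4 it stands ortho to a large group. Nothing measured here separates an ortho placement from a para one.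

Within the data shown here, what is expected for compound 4 rests on two points: compound 3 is reported as "not active" (no number reported), and the one measured instance of bromo entering gave a number 11 percentage points lower from compound 1 to compound 2 (beyond the scatter), a lowering. Neither point argues for a rise. Compound 4 is expected to give 10% in this assay, somewhere between 0% and 28%, with a real chance that only an inactive call and no number is returned.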

Compound 4, percent growth inhibition at one concentration: 43%
Compound 4: middle estimate off by 33 percentage points, on the low side; the whole stated range lies below it.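

No step can be read from compound 3 to compound 4 in this assay: compound 3 carries no number, so the value of compound 4, 43%, has nothing to be set against. The compounds shown leave open whether the result for compound 4 goes with a bromo ortho to a large group or with the core that carries it. Nothing available bears on this result.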